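Isopropyl for chloro on the pendant phenyl: one-point displacement

A few compounds are considered here, and "the series" means these few. Any claim that something is new, unique, unknown or untested is made for them only; others in the source may bear on it.

Working notes on a small series. Compound 1 `Nc1sc(-c2ccccc2)c(-c2ccccc2)c1C(=O)c1ccc(Cl)cc1` and compound 2 `CC(C)(C)Cc1c(-c2ccc(Cl)cc2)sc(N)c1C(=O)c1ccc(Cl)cc1` share the same core, differing in their substituents. In an assay on CHO cells for displacement of a labelled ligand from adenosine receptor A3 (Homo sapiens), read by scintillation counting, tested at 10 uM (a higher number here means more inhibition at the concentration tested (going by the name of the read-out), a lower number less inhibition), compound 1 gives 1%, and in this assay compound 2 gives 1%. Compound 2 thus stands level with compound 1 at the digits shown; the two values lie within the scatter, so no order between them can be read, and both sit at the bottom of the read-out.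

Compound 3 `CC(C)c1ccc(-c2sc(N)c(C(=O)c3ccc(Cl)cc3)c2CC(C)(C)C)cc1` differs from compound 2 in one place: isopropyl in place of chloro on an aromatic carbon. Going by the values given here, no step between measured compounds is available for this change. Since both measured compounds sit at the bottom of the read-out, the step given by the estimate, a number 1 percentage points higher from compound 2 to compound 3 (within the scatter), is expected to be none beyond the scatter. In this assay compound 3 is accordingly expected to give 2%, within a range from -8% to 15%.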

Compound 3, a percentage reported as inhibition, at one concentration (the size of the read-out at that concentration, not a potency): 1%
For compound 3 the middle estimate is 1 percentage points above the measured one, within the range that was stated.
By their numbers in this assay, from the lowest: compounds 1, 2 and 3 (each within the scatter of the next).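

In this assay, isopropyl in place of chloro on the aromatic carbon, para to a large group, gives no change at the digits printed from compound 2 to compound 3 (within the scatter). Going by these compounds alone, this is the first step that changes one place only, and 4-chlorophenyl and 4-isopropylphenyl do not separate at this position, with both compounds at the bottom of the read-out. Nothing measured here bears on why the read-out stays there.

Since the step lies at the bottom of the read-out, it cannot tell whether this position has any influence on displacement of the labelled ligand. From the compounds shown here alone, whether an amine or a carboxylic acid at this place would bring the read-out clear of the scatter remains open, as does whether a change elsewhere on the shared core would do so.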